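Working notes on compound 4

A few compounds are considered here, and "the series" means these few. Any claim that something is new, unique, unknown or untested is made for them only; others in the source may bear on it.

Measured so far:
compound 1, `NC(=O)c1ccc(-n2ccc3ccncc32)cc1`: 60%
compound 2, `N#Cc1ccc(Oc2cccnc2)cc1Oc1ccccc1`: 78%
compound 3, `N#Cc1ccc(Oc2cccnc2)c(F)c1`: 52%

In an assay on isolated protein for inhibition of Aromatase (Homo sapiens), read by fluorescence, tested at 1 uM (a lower number here means less inhibition, a higher number more inhibition at the concentration tested (going by the name of the read-out)), compound 1 stands second highest of the three numbers; compound 3 lies within the scatter of it, while compound 2 gives a number beyond the scatter above it. Among the compounds with values here, no pair of measured compounds differs in only one place, so no single step is known. Compound 4, `Ic1ccc(-n2ccc3ccncc32)cc1`, differs from compound 1 by iodo in place of carbamoyl on an aromatic carbon. Within the data shown here, none of the measured compounds shows what leaving out a carbamoyl or bringing in an iodo does here, so the direction stays open. The step is expected to stay within the scatter: a number 5 percentage points lower from compound 1 to compound 4 (within the scatter). Compound 4 is estimated at 55%, with a range from 25% to 80%.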

Compound 4, a percentage reported as inhibition, at one concentration (the size of the read-out at that concentration, not a potency): 26%
Compound 4: middle estimate off by 29 percentage points, on the high side; the measured number falls inside the stated range.
By their numbers in this assay, from the lowest: compound 4; then compounds 3 and 1 (each within the scatter of the next); then compound 2.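

In this assay, within the data shown here, the first comparison in one place gives a number 34 percentage points lower from compound 1 to compound 4 (beyond the scatter) and shows that this aromatic carbon, para to a group of 9 heavy atoms, is sensitive to what it carries. Iodo in place of carbamoyl is a large step down, something the earlier compounds, with no pair differing in one place, could not show. Nothing at hand accounts for the size or direction of this step.

The compounds shown do not separate the effect of leaving out carbamoyl from that of bringing in iodo. From the compounds shown here alone, how a carboxylic acid or an amine on this carbon would read also stays open.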